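The source may hold more compounds than are shown below. What is called first, only, known or untested is meant among the compounds shown, and "the series" means these compounds.

Of the compounds shown here, three sharing one core have been tested in a functional assay on cells (T-cell, Homo sapiens) for inhibition; on this read-out lower numbers stand for stronger inhibition and higher numbers for weaker inhibition. Compound 1 `COc1ccc(-c2cnc3nc(N)nc(N4CCN(Cc5ccccc5F)CC4)c3n2)cc1OC` gives 700 nM. Compound 3 `COc1ccc(-c2cnc3nc(N)nc(N4CCC(C)CC4)c3n2)cc1OC` gives 800 nM in the same test; that number sits within the usual scatter of repeated measurements relative to compound 1, so the two cannot be told apart on these data. Compound 2 `CCOc1ccc(-c2cnc3nc(N)nc(OC(C)C)c3n2)cc1` gives 10000 nM, a number that lies beyond the scatter from compound 1. Among the three numbers shown, the number of compound 1 is the lowest.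

Compound 4 `COc1ccc(-c2cnc3nc(N)nc(N4CCN(C(=O)Nc5ccc(F)cc5)CC4)c3n2)cc1OC` has not yet been measured. It differs from compound 1 in one place: (4-fluorophenyl)carbamoyl in place of 2-fluorobenzyl on an amine nitrogen in a ring. Among the measured compounds shown here, no pair of measured compounds differs in a single place, so there is no measured step to guide an expectation for this change. The change is expected to move the number in this assay only modestly, if at all, and the step of a 1.4-fold higher number from compound 1 to compound 4 (0.15 log units; within the scatter) is estimated to stay close to the scatter. Compound 4 is expected to give 1000 nM, with a range from 300 nM to 3500 nM.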

Compound 4, half-maximal inhibitory concentration: 7 nM
Beside the measured number, compound 4's estimate is 140-fold (2.15 log units) above it; measured number below the stated range.
By their numbers in this assay, from the lowest: compound 4; then compounds 1 and 3 (each within the scatter of the next); then compound 2.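

With the shared core unchanged, placing (4-fluorophenyl)carbamoyl instead of 2-fluorobenzyl on the amine nitrogen in the ring gives, in this assay, a 100-fold lower number from compound 1 to compound 4 (2.00 log units; beyond the scatter). Among the compounds shown here, the earlier compounds offered no step at a single place, so this is the first sign that the group on this nitrogen can shift the number far beyond the scatter. No supporting measurement bears on why this change has so large an effect.

The change alters several features at once, so the compounds shown do not separate the contribution of the carbonyl and the amide hydrogen from that of moving from a 2-fluoro to a 4-fluoro group. As far as these compounds go, it also remains open whether a simpler group on this nitrogen, such as an acetyl or an unsubstituted phenylcarbamoyl, would keep a number this low.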